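A few compounds are considered here, and "the series" means these few. Any claim that something is new, unique, unknown or untested is made for them only; others in the source may bear on it.

Working notes on the thiosemicarbazone series.

Compound 1 `CC1=CC[C@H](C(C)(C)NC(=S)N/N=C/c2ccccc2)CC1` and compound 2 `COc1ccc(/C=N/NC(=S)NC(C)(C)[C@H]2CC=C(C)CC2)cc1` share one core and differ by methoxy in place of hydrogen on an aromatic carbon. In a functional assay on PC-3 cells (Homo sapiens) for inhibition, read by sulforhodamine B assay, with a stated time of 48 h (a higher number here means a weaker inhibitor of growth, a lower number a stronger inhibitor of growth), compound 1 gives 5700 nM. In this assay compound 2 gives 1200 nM. The step of a 4.8-fold lower number from compound 1 to compound 2 (0.68 log units; beyond the scatter) is the only measured instance of this change among the compounds shown.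

Compound 3 `CC1=CC[C@H](C(C)(C)NC(=S)N/N=C(\C)c2ccccc2)CC1` sits on a second core; how the two cores differ is not broken down here. In this assay compound 3 reaches only the limit of the assay, > 100000 nM, and no number is known for it. This is the case described by the limit of > 100000 nM in this assay, at which 1 of the 3 values shown sits.

Compound 4 `COc1ccc(/C(C)=N/NC(=S)NC(C)(C)[C@H]2CC=C(C)CC2)cc1` differs from compound 3 by methoxy in place of hydrogen on an aromatic carbon, the same change as that from compound 1 to compound 2, on the same kind of place. Whether the step repeats on the second core cannot be read from one instance, and the starting point for compound 3 is a limit rather than a number. A step of an at least 2.5-fold lower number from compound 3 to compound 4 (0.39 log units; beyond the scatter) is expected, resting on the step from compound 1 to compound 2, a 4.8-fold lower number from compound 1 to compound 2 (0.68 log units; beyond the scatter), applied from the limit. Compound 4 is therefore estimated at 40000 nM in this assay, between 8000 nM and 200000 nM, with a real chance that only a limit is reported again.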

Compound 4, concentration for total growth inhibition: > 100000 nM
Compound 4: a limit, no number (the forecaster's own chance of this, stated with the estimate: 45%); at least 2.5-fold (0.39 log units) between middle value and limit.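

Within the data shown here, compound 3 and compound 4 both stand at a limit in this assay, and no step between them can be read: the limit of > 100000 nM in this assay, at which 2 of the 4 values shown sit.

The compounds shown leave open whether methoxy in place of hydrogen on an aromatic carbon changes the read-out at all on the core of compound 3, as it does from compound 1 to compound 2.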